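This account rests on a few compounds, and the source may have more. Where it says the series, first, only, none or still open, it means among the compounds named here.

Measured compounds:
Compound 1 `NS(=O)(=O)c1ccc(Nc2nccc(Nc3ccc4cn[nH]c4c3)n2)cc1`: 22000 nM
Compound 2 `Cc1cccc(Nc2nccc(Nc3ccc4nc[nH]c4c3)n2)c1`: 20000 nM
Compound 3 `Cc1ccc(Nc2nccc(Nc3ccc4cn[nH]c4c3)n2)cc1`: 18000 nM

These three compounds were tested in an ADME assay on HepG2 cells (Homo sapiens) for inhibition, read by fluorescence and resazurin assay, with a stated time of 72 h (a higher number here means a weaker inhibitor, a lower number a stronger inhibitor), and their numbers sit close together. Compound 3 gives the lowest of the three, yet its nearest neighbour compound 2 and its furthest neighbour compound 1 both lie within the scatter of it, so no order among the three can be read from these values. For the measured compounds named here, the single step with one change, a 1.2-fold lower number from compound 1 to compound 3 (0.09 log units; within the scatter), shows that replacing sulfamoyl with methyl on the shared core left the result within the scatter.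

Compound 4 `NC(=O)c1ccc(Nc2nccc(Nc3ccc4cn[nH]c4c3)n2)cc1` is the next compound, not yet measured in this assay. It differs from compound 3 in one place: carbamoyl in place of methyl on an aromatic carbon. The step from compound 1 to compound 3 bears on this, since it also exchanges a group carrying a hydrogen-bond donor and acceptor for methyl at the same place, and it stayed within the scatter. On that basis the step of a 1.1-fold higher number from compound 3 to compound 4 (0.05 log units; within the scatter) is expected to stay within the scatter, in no particular direction. Compound 4 is therefore estimated to give 20000 nM in this assay, with a range from 10000 nM to 40000 nM.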

Compound 4, half-maximal inhibitory concentration: 16000 nM
The estimate for compound 4 lay 1.3-fold (0.10 log units) above the measured number, and the stated range covers the measured number.
By their numbers in this assay, from the lowest: compounds 4, 3, 2 and 1 (each within the scatter of the next).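

In this assay this place, on an aromatic carbon para to a large group, has now taken three groups on the shared core, and none of the exchanges among them moves the number beyond the scatter. Carbamoyl in place of methyl gives a 1.1-fold lower number from compound 3 to compound 4 (0.05 log units; within the scatter) and carbamoyl in place of sulfamoyl gives a 1.4-fold lower number from compound 1 to compound 4 (0.14 log units; within the scatter) so the earlier single exchange of sulfamoyl for methyl is no longer alone, and the assay does not separate methyl, which counts no hydrogen-bond donor or acceptor, from carbamoyl, which counts one of each. The compounds therefore show this place tolerating these three groups with no order among them, and no evidence is available that would explain this result.

For the compounds shown here, the compounds leave open whether a carboxylic acid, an amine or a longer chain at this same place would also stay within the scatter or would be the first group to shift the number beyond it. They also leave open whether carbamoyl would behave in the same way on a different core, since all of these comparisons rest on a single shared core.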